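Swapping an amino group for chloro on a shared core

This account rests on a few compounds, and the source may have more. Where it says the series, first, only, none or still open, it means among the compounds named here.

Three closely related compounds have been tested in an ADME assay on H9 cells (Homo sapiens) for cytotoxicity, read by MTT assay, with a stated time of 7 days; on this read-out lower numbers stand for higher toxicity in this test and higher numbers for lower toxicity in this test. Compound 1, `COc1ccccc1NC(=O)c1cc(N)ccc1Sc1ccc([N+](=O)[O-])cc1`, gives 506000 nM. Compound 2, `COc1ccccc1NC(=O)c1cscc1Sc1ccc([N+](=O)[O-])cc1`, gives 518000 nM, and compound 3, `COc1ccccc1NC(=O)c1cccnc1Sc1ccc([N+](=O)[O-])cc1`, gives 525000 nM. Compound 1 has the lowest of these three numbers, yet its gaps to compound 2 and to compound 3 both lie within the scatter, so the three cannot be told apart. Compound 4, `COc1ccccc1NC(=O)c1cc(Cl)ccc1Sc1ccc([N+](=O)[O-])cc1`, is not yet measured; it differs from compound 1 in one place: chloro in place of amino on an aromatic carbon. Among the measured compounds shown here, with no measured step of this kind to lean on, the change is expected to move the number by no more than the scatter, the step of a 1.1-fold lower number from compound 1 to compound 4 (0.05 log units; within the scatter) being the estimate. Compound 4 is therefore expected to give about 450000 nM, within 200000 nM to 1000000 nM.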

Compound 4, half-maximal cytotoxic concentration: 483000 nM
For compound 4 the middle estimate is 1.1-fold (0.03 log units) below the measured one; the range from low to high includes it.
By their numbers in this assay, from the lowest: compounds 4, 1, 2 and 3 (each within the scatter of the next).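

In this assay, among the compounds shown here, chloro in place of amino on this aromatic carbon gives a 1.0-fold lower number from compound 1 to compound 4 (0.02 log units; within the scatter), the only step measured at this position. The two compounds therefore cannot be told apart here, even though amino carries a hydrogen-bond donor and acceptor and chloro carries neither. Nothing available explains this result.

From the compounds shown here alone, whether a carboxylic acid or a longer alkyl chain at the same place would also stay within the scatter remains open. So does whether this swap would behave the same way on a different core.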